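Intrinsic activity after swapping the ether substituent for a pyridyl group

The source may hold more compounds than are shown below. What is called first, only, known or untested is meant among the compounds shown, and "the series" means these compounds.

Of the compounds shown here, two have been measured in an in vitro functional assay on HEK293S cells with Glucose-dependent insulinotropic receptor (Homo sapiens) as the target, read by HTRF and cAMP accumulation, with a stated time of 45 min; on this read-out higher numbers stand for larger maximal responses and lower numbers for smaller maximal responses. Compound 1 `CC(C)(C)OC(=O)N1C[C@@H]2CC[C@H]1CN2c1ncc(OCc2ccc(S(C)(=O)=O)cc2)cn1` gives 85% in this assay. Compound 2 `C[C@@H]1CN(C(=O)OC(C)(C)C)CCN1c1ncc(OCC2CCN(S(C)(=O)=O)CC2)cn1` gives 99% in this assay, the higher of the two numbers; compound 1 lies lower by a gap beyond the scatter. Going by the values given here, no pair of measured compounds differs in a single place, so the two values stand on their own.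

Compound 3 `Cc1cnccc1COc1cnc(N2CCN(C(=O)OC(C)(C)C)C[C@H]2C)nc1` is not yet measured in this assay. It differs from compound 2 in one place: 3-methylpyridin-4-yl in place of 1-(methylsulfonyl)piperidin-4-yl on a saturated chain carbon bound to an oxygen on an aromatic ring. Compound 1 also carries an aromatic ring at that place and gives 85% in this assay, somewhat under compound 2. On that basis the step from compound 2 to compound 3 is expected to be a small decrease, a number 9 percentage points lower from compound 2 to compound 3 (within the scatter), close to the edge of the scatter. Compound 3 is estimated to reach 90% in this assay, within 75% to 102%.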

Compound 3, intrinsic activity: the largest response reached, in percent of the reference agonist's: 68%
The estimate for compound 3 lay 22 percentage points above the measured number, outside the stated range (below it).
By their numbers in this assay, from the lowest: compound 3; then compound 1; then compound 2.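

In this assay this position is the only place where a single change can be read so far, and the change gives a number 31 percentage points lower from compound 2 to compound 3 (beyond the scatter) in the maximal response. The group on the saturated chain carbon bound to an oxygen on an aromatic ring therefore matters for this read-out, and 3-methylpyridin-4-yl does not keep the level reached with 1-(methylsulfonyl)piperidin-4-yl. No supporting data bear on the reason for this step.

This one step cannot separate the loss of the methylsulfonyl group from the exchange of the ring itself, and compound 1 differs from compound 3 in more than one place, so it cannot settle the point. Open too, on these data alone, is how the response would stand with an unsubstituted piperidin-4-yl, a pyridin-4-yl without the methyl group or a phenyl ring bearing a methylsulfonyl group at this place on the same core.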